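A hydroxy gives way to a methylsulfanylethyl chain

This account rests on a few compounds, and the source may have more. Where it says the series, first, only, none or still open, it means among the compounds named here.

Of the compounds shown here, three on a shared core have been measured in an assay on isolated protein for inhibition of Nitric oxide synthase, inducible (Homo sapiens), with a stated time of 30 min; a lower number here means a stronger inhibitor, a higher number a weaker inhibitor. Compound 1 `Cc1cc(N)nc(CC(C)C)c1` carries an isobutyl chain on the core and gives 193 nM. Compound 3 `Cc1cc(N)nc(CC(C)O)c1` differs from it by a hydroxy in place of methyl on a saturated chain carbon bound to two saturated chain carbons, and compound 3 gives 1780 nM. Compound 2 `COC(C)Cc1cc(C)cc(N)n1` carries a methoxy at that carbon instead; for compound 2 this assay reports only a limit, > 5000 nM. Among the numbers shown, compound 3 stands highest, with compound 1 nearest at a 9.2-fold higher number from compound 1 to compound 3 (0.96 log units; beyond the scatter). The other two steps also run through this position: an at least 25-fold higher number from compound 1 to compound 2 (1.41 log units; beyond the scatter), and an at least 2.8-fold lower number from compound 2 to compound 3 (0.44 log units; beyond the scatter).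

Compound 4 `CSCCC(C)Cc1cc(C)cc(N)n1` has not yet been measured. It is reached from compound 3 by 2-(methylsulfanyl)ethyl in place of hydroxy on a saturated chain carbon bound to two saturated chain carbons. For the measured compounds named here, the steps that bear on this change are a 9.2-fold higher number from compound 1 to compound 3 (0.96 log units; beyond the scatter), where the hydroxy entered, and an at least 25-fold higher number from compound 1 to compound 2 (1.41 log units; beyond the scatter), where an oxygen-bearing group was also costly. Because the step of a 9.2-fold higher number from compound 1 to compound 3 (0.96 log units; beyond the scatter) runs toward a higher number when the hydroxy enters, its removal here leads one to expect a modest to large step toward a lower number in this assay for compound 4, of roughly a 12-fold lower number from compound 3 to compound 4 (1.07 log units; beyond the scatter). Compound 4 is therefore estimated at 150 nM, with a range from 40 nM to 800 nM.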

Compound 4, half-maximal inhibitory concentration: > 5000 nM
Compound 4 ended at the assay's limit; the forecaster's own chance of this, stated with the estimate: 5%; middle value at least 33-fold (1.52 log units) from the limit.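

In this assay compound 4 gives > 5000 nM, which is a limit of the assay and not a number. Taking out the hydroxy did not recover the strength of compound 1, as the 2-(methylsulfanyl)ethyl chain gives an at least 2.8-fold higher number from compound 3 to compound 4 (0.44 log units; beyond the scatter), and set against the isobutyl chain it gives an at least 25-fold higher number from compound 1 to compound 4 (1.41 log units; beyond the scatter), so at this saturated chain carbon a replacement for methyl can be costly without any oxygen on that carbon and without a hydrogen-bond donor in the group. The step between the methoxy and the 2-(methylsulfanyl)ethyl chain cannot be read, and how far these two groups lie beyond the range of the assay stays unknown: the limit of > 5000 nM in this assay, at which 2 of the 4 values shown sit.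

The compounds shown leave open whether the cost of the 2-(methylsulfanyl)ethyl chain follows from its length or from its sulfur, a question that a plain propyl or butyl chain on this carbon would address. They also leave open how an ethyl group, only slightly longer than the methyl of compound 1, or an amine at the same carbon would read.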